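Swapping a pyridine ring for phenyl in a flavonol series

The source may hold more compounds than are shown below. What is called first, only, known or untested is meant among the compounds shown, and "the series" means these compounds.

Measured so far:
compound 1, `COc1ccc(-c2oc3c(CNCc4ccncc4)c(O)ccc3c(=O)c2O)c(OC)c1` — 56700 nM
compound 2, `CCN(CC)Cc1c(O)ccc2c(=O)c(O)c(-c3cccc(Cl)c3Cl)oc12` — 60400 nM

Of the compounds shown here, two sharing a common core have been tested in a functional assay on RPMI-8226 cells (Homo sapiens) for inhibition, read by CCK-8 assay, with a stated time of 72 h; on this read-out lower numbers stand for stronger inhibition and higher numbers for weaker inhibition. Compound 1 gives 56700 nM and compound 2 gives 60400 nM; these two numbers lie within the scatter of each other, so the two compounds stand level in this assay, and both show only weak inhibition.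

Compound 3, `COc1ccc(-c2oc3c(CNCc4ccccc4)c(O)ccc3c(=O)c2O)c(OC)c1`, has not been measured. It differs from compound 1 by a single change, (phenyl in place of pyridin-4-yl on a saturated chain carbon bound to an amine nitrogen). Among the measured compounds shown here, no step between measured compounds bears on this change, so nothing in the data points to a direction. With both measured numbers standing in the same weak range, the step from compound 1 to compound 3 is expected to be small, most likely none beyond the scatter: a 1.1-fold lower number from compound 1 to compound 3 (0.05 log units; within the scatter). Compound 3 is therefore estimated at 50000 nM, within a range of 20000 nM to 120000 nM, in this assay.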

Compound 3, half-maximal inhibitory concentration: 14900 nM
Compound 3: middle estimate off by 3.4-fold (0.53 log units), on the high side, outside the stated range (below it).
By their numbers in this assay, from the lowest: compound 3; then compounds 1 and 2 (each within the scatter of the next).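

In this assay, phenyl in place of pyridin-4-yl on a saturated chain carbon bound to an amine nitrogen gives a 3.8-fold lower number from compound 1 to compound 3 (0.58 log units; beyond the scatter), so this position responds to the ring it carries, something the level values of the first two compounds could not show. Both rings are six-membered and aromatic, so the modest step goes with the exchange of the ring nitrogen for carbon alone. Nothing measured here explains why the all-carbon ring gives the lower number.

The compounds shown leave open whether pyridin-3-yl, cyclohexyl or phenethyl would move the number further in this place. Going by these compounds, compound 2 carries neither ring, so it also remains unknown whether the same swap gives a similar step with other groups on the shared core.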